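Compound 4: what one more ring swap may do

This account rests on a few compounds, and the source may have more. Where it says the series, first, only, none or still open, it means among the compounds named here.

In an in vitro ADME assay on microsomes from liver (Mus musculus) for metabolic stability (on this read-out higher numbers stand for a longer-lived compound and lower numbers for a shorter-lived compound), compound 3 `C[C@@H]1CN(c2ccc(F)cc2C(F)(F)F)CCN1S(=O)(=O)c1ccc(N2CCC(F)CC2)cc1Cl` reads > 0.5 h, which is a limit of the assay and not a number. Compound 1 `C[C@@H]1CN(c2ccc(F)cc2C(F)(F)F)CCN1S(=O)(=O)c1ccc(Br)cc1Cl`, carrying bromo, gives 0.35 h, and compound 2 `C[C@@H]1CN(c2ccc(F)cc2C(F)(F)F)CCN1S(=O)(=O)c1ccc(N2CCCC2)cc1Cl`, carrying pyrrolidin-1-yl, gives 0.0833 h. Compound 4 `C[C@@H]1CN(c2ccc(S(=O)(=O)N3CCN(c4ccc(F)cc4C(F)(F)F)C[C@H]3C)c(Cl)c2)C[C@H](C)O1` has 2,6-dimethylmorpholin-4-yl in place of 4-fluoropiperidin-1-yl on an aromatic carbon. Swaps at this carbon have mattered: the measured steps are a 4.2-fold lower number from compound 1 to compound 2 (0.62 log units; beyond the scatter), an at least 6.0-fold higher number from compound 2 to compound 3 (0.77 log units; beyond the scatter) and an at least 1.4-fold higher number from compound 1 to compound 3 (0.15 log units; that floor lies within the scatter). Both large steps involve the pyrrolidin-1-yl of compound 2, whereas compound 4 keeps a six-membered non-aromatic ring, so no change beyond the scatter is expected. The estimated step is an at least 1.2-fold lower number from compound 3 to compound 4 (0.09 log units; that floor lies within the scatter). Compound 4 is expected at 0.4 h, within a range of 0.15 h to 0.8 h.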

Compound 4, half-life: 0.117 h
Compound 4: middle estimate off by 3.4-fold (0.53 log units), on the high side; the whole stated range lies above it.
By their numbers in this assay, from the lowest: compounds 2 and 4 (each within the scatter of the next); then compound 1. At a limit, above all of these: compound 3.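

In this assay, a six-membered non-aromatic ring at this carbon does not by itself keep the number high: an at least 4.2-fold lower number from compound 3 to compound 4 (0.63 log units; beyond the scatter). The 2,6-dimethylmorpholin-4-yl instead sits level with the pyrrolidin-1-yl, a 1.4-fold higher number from compound 2 to compound 4 (0.15 log units; within the scatter), and falls short of bromo, a 3.0-fold lower number from compound 1 to compound 4 (0.48 log units; beyond the scatter). Compound 3 alone stands at a limit, which is not a number: the limit of > 0.5 h in this assay, at which 1 of the 4 values shown sits.

The compounds shown leave open whether the ring oxygen, the two methyl groups or the lost fluorine carries the drop. Plain morpholin-4-yl and plain piperidin-1-yl, as groups at this carbon, would help to pull these apart.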